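The source may hold more compounds than are shown below. What is called first, only, known or untested is meant among the compounds shown, and "the series" means these compounds.

Among the measured compounds shown here, compound 2 `O=C(Nc1sc2c(c1C(=O)NNc1ccc(Cl)cc1)CCCCC2)NS(=O)(=O)c1ccccc1` is the only compound here with a numbered reading: in a functional assay on cells (Leukemia cell, Homo sapiens) for inhibition, with a stated time of 48 h (a lower number here means a stronger inhibitor of growth, a higher number a weaker inhibitor of growth), compound 2 gives 30600 nM. Compound 1 `CN1CCN(C(=O)c2c(NC(=O)NS(=O)(=O)c3ccccc3)sc3c2CCCCC3)CC1` carries a 4-methylpiperazin-1-yl group on the same carbonyl carbon, and in this assay compound 1 reaches only the assay limit of > 100000 nM. For the measured compounds named here, the single measured step, an at least 3.2-fold lower number from compound 1 to compound 2 (0.51 log units; beyond the scatter), is the only guide, and it shows that a 4-methylpiperazin-1-yl group on that carbonyl sits at the limit of > 100000 nM in this assay, at which 1 of the 2 values shown sits. Compound 3 `O=C(Nc1sc2c(c1C(=O)N1CCN(c3ccccc3)CC1)CCCCC2)NS(=O)(=O)c1ccccc1` differs from compound 2 in one place: 4-phenylpiperazin-1-yl in place of ((4-chlorophenyl)amino)amino on a carbonyl carbon. A piperazine ring of the kind found in compound 1 thus returns, while a phenyl ring as in compound 2 is kept. On that basis the number is expected to move upward, a weakening step of roughly a 2.0-fold higher number from compound 2 to compound 3 (0.29 log units; within the scatter). Compound 3 is therefore estimated at 60000 nM, with a range from 15000 nM to 200000 nM, and a fair chance that only a limit is reported.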

Compound 3, concentration for 50% growth inhibition: > 100000 nM
Compound 3 ended at the assay's limit; the forecaster's own chance of this, stated with the estimate: 45%; middle value at least 1.6-fold (0.22 log units) from the limit.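

Replacing ((4-chlorophenyl)amino)amino with 4-phenylpiperazin-1-yl on the carbonyl carbon gives an at least 3.2-fold higher number from compound 2 to compound 3 (0.51 log units; beyond the scatter) in this assay. A phenyl ring in the entering group is therefore not enough to keep a measurable reading, and a piperazine ring with phenyl on its ring nitrogen does no better here than one with methyl, as far as the data can show. Compound 1 and compound 3 both end at a limit rather than a number, so the step between them cannot be read: the limit of > 100000 nM in this assay, at which 2 of the 3 values shown sit.

The compounds shown leave open whether the chlorine on the phenyl ring of compound 2 contributes to its reading. They also leave open whether an open-chain group such as benzylamino on that carbonyl carbon would give a number rather than a limit.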